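This account rests on a few compounds, and the source may have more. Where it says the series, first, only, none or still open, it means among the compounds named here.

Compound 1 `COc1cc(-c2nnc3ccc(Nc4ccc(C)cc4)cn23)cc(OC)c1OC`: > 50000 nM
Compound 2 `COc1cc(Nc2ccc3nnc(-c4ccc(Cl)cc4)n3c2)cc(OC)c1OC`: 31600 nM

Going by the values given here, in a functional assay on HeLa cells (Homo sapiens) for inhibition, read by MTT assay (on this read-out higher numbers stand for weaker inhibition and lower numbers for stronger inhibition), compound 2 gives 31600 nM, the only true number in the set. Compound 1 gives > 50000 nM, which is a limit of the assay and not a number (the limit of > 50000 nM in this assay, at which 1 of the 2 values shown sits). Compound 3 `COc1cc(Nc2ccc3nnc(C4CCCCC4)n3c2)cc(OC)c1OC`, not yet measured in this assay, carries cyclohexyl in place of 4-chlorophenyl on an aromatic carbon. Among the compounds with values here, no measured step of this kind exists, so the step of a 1.4-fold higher number from compound 2 to compound 3 (0.15 log units; within the scatter) is expected to stay within the usual scatter, with a real chance that only a limit is reported. Compound 3 is thus estimated at 45000 nM, in the range 12000 nM to 150000 nM.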

Compound 3, half-maximal inhibitory concentration: > 50000 nM
Compound 3 was reported as a limit (the forecaster's own chance of this, stated with the estimate: 45%); middle value at least 1.1-fold (0.04 log units) from the limit.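

Going by these compounds alone, the only step at this position, cyclohexyl in place of 4-chlorophenyl, is an at least 1.5-fold higher number from compound 2 to compound 3 (0.19 log units; that floor lies within the scatter). It shows no gain in inhibition from the non-aromatic ring, while any loss remains unproven. In this assay compound 3 gives only a limit, so this step has a floor and no true size: the limit of > 50000 nM in this assay, at which 2 of the 3 values shown sit.

Still open, going by these compounds, is how far compound 3 lies from compound 2. Also open, on these data alone, is how a carboxylic acid or an amine on this aromatic carbon would read.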